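A few compounds are considered here, and "the series" means these few. Any claim that something is new, unique, unknown or untested is made for them only; others in the source may bear on it.

Three compounds have been measured so far:

compound 1, `O=C(/C=C/c1ccc(Cl)cc1)NS(=O)(=O)c1ccc(F)cc1`, 2 ug/mL
compound 2, `O=C(/C=C/c1ccc(Cl)cc1)NS(=O)(=O)c1ccc(Cl)cc1`, 2.5 ug/mL
compound 3, `O=C(/C=C/c1ccc(Br)cc1)NS(=O)(=O)c1ccc(F)cc1`, 1.2 ug/mL

All three were tested in a functional assay on B16-F10 cells (Mus musculus) for antiproliferative activity, read by ELISA and MTT assay, with a stated time of 48 h; a higher number here means a weaker inhibitor, a lower number a stronger inhibitor. They share one core and differ only in the halogen on one of the two outer rings. Compound 1 and compound 2 differ by chloro in place of fluoro on an aromatic carbon, and this gave a 1.3-fold higher number from compound 1 to compound 2 (0.10 log units; within the scatter). Compound 1 and compound 3 differ by bromo in place of chloro on an aromatic carbon, which gave a 1.7-fold lower number from compound 1 to compound 3 (0.22 log units; within the scatter). Within the data shown here, no step is counted between compound 2 and compound 3; their two values lie somewhat more than the usual scatter apart.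

Compound 4, `O=C(/C=C/c1ccc(Br)cc1)NS(=O)(=O)c1ccc(Cl)cc1`, has not yet been measured in this assay. It differs from compound 3 by chloro in place of fluoro on an aromatic carbon, and the place where the change is made is described in the same words as for the change from compound 1 to compound 2, so it is the same change. Because the earlier instance of it gave a 1.3-fold higher number from compound 1 to compound 2 (0.10 log units; within the scatter), only a small shift is expected here as well, about a 1.3-fold higher number from compound 3 to compound 4 (0.12 log units; within the scatter). Compound 4 is therefore estimated at 1.6 ug/mL, most likely between 0.8 ug/mL and 3.2 ug/mL.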

Compound 4, half-maximal inhibitory concentration: 5.2 ug/mL
For compound 4 the middle estimate is 3.3-fold (0.51 log units) below the measured one, and the stated range ends below it.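

In this assay, the change from 4-fluorophenyl to 4-chlorophenyl gave a 4.3-fold higher number from compound 3 to compound 4 (0.64 log units; beyond the scatter), and its size did not carry over from the earlier core: the same change on two cores in this assay, a 1.3-fold higher number (0.10 log units; within the scatter) from compound 1 to compound 2 and a 4.3-fold higher number (0.64 log units; beyond the scatter) from compound 3 to compound 4, 3.5-fold (0.54 log units) apart, beyond the scatter of two such steps

The swap of chloro for bromo on the other outer ring gave a 2.1-fold higher number from compound 2 to compound 4 (0.32 log units; beyond the scatter), which runs opposite in direction to its earlier instance: the same change on two cores in this assay, a 1.7-fold lower number (0.22 log units; within the scatter) from compound 1 to compound 3 and a 2.1-fold higher number (0.32 log units; beyond the scatter) from compound 2 to compound 4, 3.5-fold (0.54 log units) apart, beyond the scatter of two such steps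

Within these four compounds, then, the result of changing the halogen on one ring depends on which halogen the other ring carries, so a step measured on one core is a poor guide to the same step on another; each change has only two instances, however, so this shows neither why the steps differ nor whether the dependence holds more widely.

The compounds shown leave open how a group other than a halogen, such as a methoxy, a nitrile or an amine, would behave at these places. They also leave open whether such a group would show the same dependence on the opposite ring.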